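Pyrazoline sulfonamides: from a styryl group to trimethoxyphenyl

The compounds below may be only part of what the source reports. "The series", "measured", "known", "first", "only" and "open" are said of these compounds alone.

Compound 1, `Cc1cc(O)c(C2=NN(c3ccc(S(N)(=O)=O)cc3)C(c3ccccc3O)C2)cc1Cl`, gives 9880 nM in a functional assay on MDA-MB-435 cells (Homo sapiens) for antiproliferative activity, with a stated time of 48 h; on this read-out higher numbers stand for lower toxicity in this test and lower numbers for higher toxicity in this test.
Compound 2, `Cc1cc(O)c(C2=NN(c3ccc(S(N)(=O)=O)cc3)C(c3ccccc3Cl)C2)cc1Cl`, gives 8320 nM in this assay.
Compound 3, `Cc1cc(O)c(C2=NN(c3ccc(S(N)(=O)=O)cc3)C(/C=C/c3ccccc3)C2)cc1Cl`, gives 59500 nM in this assay.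

Compound 3 stands with the highest number of the three; compound 1 is nearest, compound 2 furthest, and both gaps lie beyond the scatter. Compound 4, `COc1ccc(C2CC(c3cc(Cl)c(C)cc3O)=NN2c2ccc(S(N)(=O)=O)cc2)c(OC)c1OC`, is not yet measured. It differs from compound 3 in one place: 2,3,4-trimethoxyphenyl in place of 2-phenylethenyl on a saturated ring carbon. Going by the values given here, the steps that bear on this change run the other way round: a 2-phenylethenyl group in place of a 2-hydroxyphenyl or 2-chlorophenyl group gave a 6.0-fold higher number from compound 1 to compound 3 (0.78 log units; beyond the scatter) and a 7.2-fold higher number from compound 2 to compound 3 (0.85 log units; beyond the scatter). Among the compounds with values here, putting an aromatic ring back onto that saturated ring carbon is therefore expected to bring the number down again in this assay, though the 2,3,4-trimethoxyphenyl group has no direct counterpart among the measured compounds, so the size is uncertain. For compound 4 the estimate is 12000 nM, within a range of 4000 nM to 40000 nM, meaning an expected step of a 5.0-fold lower number from compound 3 to compound 4 (0.70 log units; beyond the scatter).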

Compound 4, concentration lethal to 50% of the cells: > 10 nM
Compound 4: no number, only a limit (the forecaster's own chance of this, stated with the estimate: 5%); the middle value lies beyond the limit too.
By their numbers in this assay, from the lowest: compounds 2 and 1 (each within the scatter of the next); then compound 3.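

In this assay compound 4 gives > 10 nM, which is a limit and not a number, and its steps from compound 1, compound 2 and compound 3 cannot be read. The compounds shown leave open how 2,3,4-trimethoxyphenyl compares with 2-phenylethenyl, 2-hydroxyphenyl or 2-chlorophenyl on that saturated ring carbon in this assay.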